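Adding a fluorine to the ester-bearing ring of compound 2

The compounds below may be only part of what the source reports. "The series", "measured", "known", "first", "only" and "open" are said of these compounds alone.

Compound 2 `COC(=O)c1ccc(C(=O)Nc2cccc(-c3cc(C(=O)Nc4ccncc4F)ccc3CN)c2)cc1` was tested in an assay on cells for inhibition of Rho-associated protein kinase 2 (Homo sapiens), read by radiometric assay and 33P incorporation, in the presence of a further agent that is not named here (on this read-out lower numbers stand for stronger inhibition and higher numbers for weaker inhibition), and gives 3.1 nM. Going by the values given here, the only other compound measured, compound 1 `COCCOC(=O)c1ccc(F)c(C(=O)Nc2cccc(-c3cc(C(=O)Nc4ccncc4F)ccc3CN)c2)c1`, gives 2.2 nM in this assay; the two numbers lie within the usual scatter of each other, so compound 2 is neither separated from nor ranked against compound 1 on this read-out. Compound 3 `COC(=O)c1ccc(F)c(C(=O)Nc2cccc(-c3cc(C(=O)Nc4ccncc4F)ccc3CN)c2)c1` has not yet been measured. It differs from compound 2 in one place: 2-fluoro-5-(methoxycarbonyl)phenyl in place of 4-(methoxycarbonyl)phenyl on a carbonyl carbon. Compound 3 combines the fluorine found in compound 1 with the methyl ester of compound 2, and both of those measured compounds sit close together. The change from compound 2 to compound 3 is therefore expected to give a step of a 1.2-fold lower number from compound 2 to compound 3 (0.09 log units; within the scatter) in this assay, which is no step beyond the scatter. Compound 3 is estimated to give 2.5 nM in this assay, with a likely range from 1.2 nM to 5.5 nM.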

Compound 3, half-maximal inhibitory concentration: 1.4 nM
Beside the measured number, compound 3's estimate is 1.8-fold (0.25 log units) above it; the range from low to high includes it.
By their numbers in this assay, from the lowest: compounds 3, 1 and 2 (each within the scatter of the next, the first and the last beyond it).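

Going by these compounds alone, the swap of 4-(methoxycarbonyl)phenyl for 2-fluoro-5-(methoxycarbonyl)phenyl gives a 2.2-fold lower number from compound 2 to compound 3 (0.35 log units; beyond the scatter), the first step in this set that lies beyond the usual scatter, so this position on the carbonyl carbon can register a change in inhibition. The end of the ester chain shows no such separation: hydrogen in place of methoxymethyl gives a 1.6-fold lower number from compound 1 to compound 3 (0.20 log units; within the scatter), so the methyl ester and the longer ester of compounds 1 and 3 cannot be told apart here. Nothing measured alongside these numbers explains the step.

On these data alone, the step to compound 3 adds a fluorine and also changes where the ester sits on the ring, so the share of each remains unknown. As far as these compounds go, whether a carboxylic acid or a primary amide could stand in place of the ester also remains open.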